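Fluoro to bromo swap: compound 3 to compound 4

This account rests on a few compounds, and the source may have more. Where it says the series, first, only, none or still open, it means among the compounds named here.

Measured so far in a toxicity assay on HCT-116 cells (Homo sapiens) for cytotoxicity, read by MTT assay; on this read-out higher numbers stand for weaker inhibition of growth and lower numbers for stronger inhibition of growth:
Compound 1, `C/C(=N\NC(N)=S)c1sc(C)nc1C`, gives > 100 ug/mL, which is a limit of the assay.
Compound 2, `C/C(=N\NC(N)=S)c1sc(-c2ccccc2)nc1C`, gives 47.3 ug/mL.
Compound 3, `C/C(=N\Nc1nc(-c2ccc(F)cc2)cs1)c1sc(C)nc1C`, gives > 100 ug/mL, which is again a limit of the assay.

Compound 3 thus stands at the limit of > 100 ug/mL in this assay, at which 2 of the 3 values shown sit; no number is known for it, only the limit. Among the compounds with values here, the one step with a number is an at least 2.1-fold lower number from compound 1 to compound 2 (0.32 log units; beyond the scatter), and it concerns phenyl in place of methyl, a different exchange at a different place from the one now in question.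

Compound 4, `C/C(=N\Nc1nc(-c2ccc(Br)cc2)cs1)c1sc(C)nc1C`, differs from compound 3 by bromo in place of fluoro on an aromatic carbon. Within the data shown here, no measured step covers a halogen exchange of this kind, so nothing among the measured compounds speaks for a shift in either direction. Given that compound 3 sits at the limit, the expected step for compound 4 in this assay is none beyond the scatter, a step that the limit leaves unreadable from compound 3 to compound 4. Compound 4 is therefore estimated at 120 ug/mL, with a range from 40 ug/mL to 350 ug/mL, and it is expected most likely to be reported again only as a limit rather than as a number.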

Compound 4, concentration for 50% growth inhibition: > 100 ug/mL
Compound 4 ended at the assay's limit; the forecaster's own chance of this, stated with the estimate: 70%; the middle value is on the limit's open side.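

Compound 3 and compound 4 both stand at a limit and not at a number, so no step can be read for bromo in place of fluoro in this assay: the limit of > 100 ug/mL in this assay, at which 3 of the 4 values shown sit.

The compounds shown leave open whether 4-fluorophenyl and 4-bromophenyl differ at all on this read-out.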